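A third methoxy group on the ester aryl ring

The source may hold more compounds than are shown below. What is called first, only, known or untested is meant among the compounds shown, and "the series" means these compounds.

Three esters sharing one core have been measured in a functional assay on HL-60 cells (Homo sapiens) for cytotoxicity, read by MTT assay, with a stated time of 24 h; a higher number here means a weaker inhibitor, a lower number a stronger inhibitor. Compound 1 `COC(=O)/C(=C\c1ccc(OC(=O)c2ccc(OC)c(OC)c2)cc1)Sc1ccnc2cc(Cl)ccc12` gives 5290 nM in this assay, the lowest of the three numbers. Compound 2 `COC(=O)/C(=C\c1ccc(OC(=O)c2c(OC)cccc2OC)cc1)Sc1ccnc2cc(Cl)ccc12` gives 37200 nM, and compound 3 `COC(=O)/C(=C\c1ccc(OC(=O)c2cc(OC)cc(OC)c2OC)cc1)Sc1ccnc2cc(Cl)ccc12` gives 10700 nM. The step of a 7.0-fold higher number from compound 1 to compound 2 (0.85 log units; beyond the scatter) and the step of a 2.0-fold higher number from compound 1 to compound 3 (0.31 log units; beyond the scatter) both moved the number upward when the methoxy pattern on the benzoate ring was rearranged.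

Compound 4 `COC(=O)/C(=C\c1ccc(OC(=O)c2ccc(OC)c(OC)c2OC)cc1)Sc1ccnc2cc(Cl)ccc12` has not yet been measured. It differs from compound 1 by methoxy in place of hydrogen on an aromatic carbon, so that the 3,4-dimethoxyphenyl becomes a 2,3,4-trimethoxyphenyl while the two original methoxy groups stay in place. The two measured steps from compound 1 both bear on this change, since each also alters the methoxy pattern of that ring, and both were weakening, one modest and one small. A modest rise in the number is therefore expected for compound 4 in this assay, with the step of a 2.3-fold higher number from compound 1 to compound 4 (0.36 log units; beyond the scatter) anticipated. The estimate for compound 4 is 12000 nM, in a range from 5000 nM to 30000 nM.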

Compound 4, half-maximal inhibitory concentration: 2080 nM
For compound 4 the middle estimate is 5.8-fold (0.76 log units) above the measured one; the measured number lies below the stated range.
By their numbers in this assay, from the lowest: compound 4; then compound 1; then compound 3; then compound 2.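

Adding a methoxy group on this aromatic carbon, ortho to a large group, with the two original methoxy groups kept, gave a 2.5-fold lower number from compound 1 to compound 4 (0.41 log units; beyond the scatter) in this assay and placed compound 4 lowest of the four, whereas both earlier changes to the methoxy pattern from compound 1 had raised the number. The arrangement of the groups on the ring, and not only their count, goes with the result: two trimethoxyphenyl esters differ, with a 5.1-fold lower number from compound 3 to compound 4 (0.71 log units; beyond the scatter) and the widest gap in the set being an 18-fold lower number from compound 2 to compound 4 (1.25 log units; beyond the scatter) here. Nothing available explains these differences.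

Going by these compounds, whether the drop is specific to methoxy remains open, since a hydroxy group, a fluorine atom or a longer ethoxy chain on the same carbon could give a different number. Whether it would persist with an amide in place of the ester linkage is also unknown.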